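The source may report more compounds than this note shows. Statements on the series, on what has been measured and on what is new or still open speak of the compounds shown alone.

Working notes on the series. Compound 1 `O=C(CCCCCCNC(=O)C(O)(O)C(F)(F)F)Nc1ncc(-c2ccc(Br)cc2)s1` and compound 2 `COc1ccc(NC(=O)CCCCCCNC(=O)C(O)(O)C(F)(F)F)cc1` share a trifluoromethyl-bearing chain amide on a seven-carbon linker. In an assay on isolated protein for inhibition of histone deacetylase 4 (Homo sapiens), read by chemiluminescence, with a stated time of 3 h (on this read-out higher numbers stand for weaker inhibition and lower numbers for stronger inhibition), compound 1 gives 1700000 nM, the highest of the two numbers; compound 2 gives 1600000 nM in this assay, and the two lie within the scatter of each other. Compound 3 `O=C(CCCCCCNC(=O)C(O)(O)C(F)(F)F)Nc1ncc(-c2ccccc2)s1` differs from compound 1 by hydrogen in place of bromo on an aromatic carbon. For the measured compounds named here, with no step between measured compounds to lean on, the expected step from compound 1 to compound 3 in this assay is a 1.1-fold higher number from compound 1 to compound 3 (0.05 log units; within the scatter), a change not beyond the scatter. Compound 3 is therefore estimated at 1900000 nM, with a range from 800000 nM to 4500000 nM.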

Compound 3, half-maximal inhibitory concentration: 2500000 nM
The estimate for compound 3 lay 1.3-fold (0.12 log units) below the measured number; the measured number falls inside the stated range.
By their numbers in this assay, from the lowest: compounds 2, 1 and 3 (each within the scatter of the next).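

Hydrogen in place of bromo gives a 1.5-fold higher number from compound 1 to compound 3 (0.17 log units; within the scatter) in this assay as the first single-place comparison in the series, so at this position, para to a large group, the bromo makes no difference beyond the scatter. All three numbers remain within the scatter of their neighbours, and this one step does not show how other changes at this position would read. No available data bear on the size of this step.
Still open, on these data alone, is how an amine or a carboxylic acid at this position would read, and whether a longer chain would shift the numbers.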